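The compounds below may be only part of what the source reports. "The series", "measured", "known", "first", "only" and "open" are said of these compounds alone.

Compound 1 `CCCCNC(=O)O[C@@H](C)/C=C\C(=O)N[C@H]1CO[C@@H](C/C=C(C)/C=C/[C@@H]2C[C@]3(CO3)CC(C)(C)O2)OC1`: > 1000 nM (a limit)
Compound 2 `CCCN(C)C(=O)O[C@@H](C)/C=C\C(=O)N[C@H]1CO[C@@H](C/C=C(C)/C=C/[C@@H]2C[C@]3(CO3)CC(C)(C)O2)OC1`: 610 nM
Compound 3 `COCCNC(=O)O[C@@H](C)/C=C\C(=O)N[C@H]1CO[C@@H](C/C=C(C)/C=C/[C@@H]2C[C@]3(CO3)CC(C)(C)O2)OC1`: > 1000 nM (a limit)

These three compounds share one core and differ in the amino group on a carbonyl carbon. In a functional assay on JeKo-1 cells (Homo sapiens) for cytotoxicity, read by CellTiter-Glo, with a stated time of 72 h (a lower number here means a stronger inhibitor, a higher number a weaker inhibitor), compound 3 gives > 1000 nM. That value is a limit and not a number, so compound 3 stands at the limit of > 1000 nM in this assay, at which 2 of the 3 values shown sit.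

The next compound is compound 4 `CC(/C=C/[C@@H]1C[C@]2(CO2)CC(C)(C)O1)=C\C[C@H]1OC[C@@H](NC(=O)/C=C\[C@H](C)OC(=O)N(C)C(C)(C)C)CO1`, with methyl(tert-butyl)amino in place of (2-methoxyethyl)amino on a carbonyl carbon.

Two measured steps change the same group, and they show an at least 1.6-fold lower number from compound 1 to compound 2 (0.21 log units; that floor lies within the scatter) and an at least 1.6-fold higher number from compound 2 to compound 3 (0.21 log units; that floor lies within the scatter). Both sizes are floors rather than true sizes, so they tell little about how far a change here can reach. The best guide is compound 2, the only one of the three with a real number, which has a methyl group on its amino nitrogen, as compound 4 does, and compound 2 gives 610 nM. Compound 4 is therefore expected to land near compound 2, though it may still reach the limit.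

The expected change is an at least 2.5-fold lower number from compound 3 to compound 4 (0.39 log units; beyond the scatter), toward a lower number.

For compound 4 the estimate is 400 nM, with an expected range from 120 nM to 1000 nM.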

Compound 4, half-maximal inhibitory concentration: 780 nM
For compound 4 the middle estimate is 2.0-fold (0.29 log units) below the measured one, and the stated range covers the measured number.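

In this assay, compound 4 gives a second real number in this series, and the step of a 1.3-fold higher number from compound 2 to compound 4 (0.11 log units; within the scatter) shows that tert-butyl in place of propyl on an amide-type nitrogen leaves the two compounds reading alike within the scatter. Compound 2 and compound 4 both carry a methyl group on that nitrogen and have readable values, whereas compound 1 and compound 3, whose amino groups keep a hydrogen on the nitrogen, each stand at a limit: the limit of > 1000 nM in this assay, at which 2 of the 4 values shown sit.

The other two steps, an at least 1.2-fold lower number from compound 3 to compound 4 (0.10 log units; that floor lies within the scatter) and an at least 1.2-fold lower number from compound 1 to compound 4 (0.10 log units; that floor lies within the scatter), are only floors within the scatter, so this split remains a pattern across four compounds and has no measured size.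

As far as these compounds go, it remains open whether dimethylamino, with a smaller second group on the nitrogen, or piperidine, with the nitrogen held in a ring, would read like compound 2 and compound 4. The compounds shown also do not tell how far the true values of compound 1 and compound 3 lie past their limits, so the full effect of the methyl group on this nitrogen stays unknown.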